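The source may report more compounds than this note shows. Statements on the series, on what has been measured and on what is new or still open speak of the compounds shown alone.

Measured compounds:
compound 1 `COc1ccc(C(=O)Oc2cc3c(cc2C)[C@@H](C(C)C)CC=C3C)cc1` – 30.8%
compound 2 `Cc1cc2c(C(C)C)ccc(C)c2cc1OC(=O)c1cccc(C(F)(F)F)c1` – "not active" (no number reported), reported without a number
compound 3 `CC1=CC[C@H](C(C)C)c2cc(C)c(OC(=O)c3cccc(C)c3)cc21` – 5.3%

In a functional assay on HCT-15 cells (Homo sapiens) for antiproliferative activity, read by sulforhodamine B assay, with a stated time of 48 h, tested at 50 uM (a lower number here means less inhibition, a higher number more inhibition at the concentration tested (going by the name of the read-out)), compound 1 gives 30.8%. In this assay compound 2 is reported as "not active" (no number reported), with no number attached. Compound 3 gives 5.3%, the lower of the two numbers in hand; its nearest neighbour is compound 1, and the step of a number 25.5 percentage points lower from compound 1 to compound 3 (beyond the scatter) lies beyond the scatter, so compound 3 stands clearly at the bottom of the numbered entries.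

Compound 4 `CC1=CC[C@H](C(C)C)c2cc(C)c(OC(=O)c3ccc([N+](=O)[O-])cc3)cc21` differs from compound 3 in one place: 4-nitrophenyl in place of 3-methylphenyl on a carbonyl carbon. Going by the values given here, no measured step covers a 4-nitrophenyl on the carbonyl carbon. Among the compounds with values here, the single step in hand, a number 25.5 percentage points lower from compound 1 to compound 3 (beyond the scatter), concerns a different exchange there, and compound 2, carrying yet another group on the carbonyl carbon, is reported without a number. The data therefore give no direction for this change, and for compound 4 a step of a number 4.7 percentage points higher from compound 3 to compound 4 (within the scatter) is expected, within the scatter. Compound 4 is estimated at 10%, within 0% to 35%.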

Compound 4, a percentage reported as inhibition, at one concentration (the size of the read-out at that concentration, not a potency): 67.8%
Compound 4: middle estimate off by 57.8 percentage points, on the low side; the measured number lies above the stated range.
By their numbers in this assay, from the lowest: compound 3; then compound 1; then compound 4.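

In this assay, the group on the carbonyl carbon proves able to carry the read-out far upward, not only downward: 4-nitrophenyl in place of 3-methylphenyl gives a number 62.5 percentage points higher from compound 3 to compound 4 (beyond the scatter) and places compound 4 highest of the three numbers. The change within the ring is also informative, as nitro in place of methoxy on an aromatic carbon gives a number 37 percentage points higher from compound 1 to compound 4 (beyond the scatter) and so the group on that ring, not the mere presence of an aromatic ring on the carbonyl carbon, sets the level of inhibition among these compounds. Nothing at hand accounts for the size of these steps.

Open is whether the nitro group itself is needed, since a 4-aminophenyl or 4-cyanophenyl group on the carbonyl carbon is not among the compounds shown. Also open, on these data alone, is how a 3-nitrophenyl group would compare with the 4-nitrophenyl group of compound 4.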